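Shifting a Fluorine on the Pendant Aromatic Ring

The compounds below may be only part of what the source reports. "The series", "measured", "known", "first", "only" and "open" are said of these compounds alone.

The study concerns an assay for inhibition of histone deacetylase 8 (Homo sapiens), read by fluorescence, with a stated time of 15 min; on this read-out lower numbers stand for stronger inhibition and higher numbers for weaker inhibition. Of the compounds shown here, three share a core and have been measured. Compound 1 `Nc1ccccc1NC(=O)c1ccc(CNC2=N[C@@H](c3ccccc3)CN2)cc1` gives 5500 nM in this assay. Compound 2 `Nc1ccccc1NC(=O)c1ccc(CNC2=N[C@@H](Cc3ccccc3)CO2)cc1` gives 63000 nM. Compound 3 `Nc1ccccc1NC(=O)c1ccc(CNC2=NC(c3ccc(F)cc3)CO2)cc1` gives 33900 nM, which places it second highest of the three numbers: its value sits within the scatter of that of compound 2, whereas compound 1 shows a clearly lower number, beyond the scatter.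

Going by the values given here, the next compound, compound 4 `Nc1ccccc1NC(=O)c1ccc(CNC2=NC(c3cccc(F)c3)CO2)cc1`, keeps every atom of compound 3 and rearranges only one group. The change is 3-fluorophenyl in place of 4-fluorophenyl on a saturated ring carbon. Among the compounds with values here, no measured pair in the set isolates a move of a fluorine around the pendant aromatic ring, so there is no step to lean on; the only guidance is that compound 3 and compound 2, which carry different groups at this position, already fall within the scatter of each other.

On that basis no shift beyond the scatter is expected from this change. Compound 4 is therefore expected to give about 32000 nM in this assay, with a plausible range from 11000 nM to 95000 nM. The estimated step of a 1.1-fold lower number from compound 3 to compound 4 (0.03 log units; within the scatter) is expected to be small, in either direction.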

Compound 4, half-maximal inhibitory concentration in the histone deacetylase 8 assay: 52200 nM
Estimate against measurement, compound 4: 1.6-fold (0.21 log units) below; low and high end bracket the measured number.
By their numbers in the histone deacetylase 8 assay, from the lowest: compound 1; then compounds 3, 4 and 2 (each within the scatter of the next).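

In the histone deacetylase 8 assay compound 3 gives 33900 nM and compound 4 gives 52200 nM. Going by these compounds alone, this is the first measured move of a fluorine around the pendant aromatic ring, and in the histone deacetylase 8 assay it gives a 1.5-fold higher number from compound 3 to compound 4 (0.19 log units; within the scatter) so on this saturated ring carbon the assay does not tell 3-fluorophenyl from 4-fluorophenyl. In a physicochemical assay for lipophilicity (on this read-out higher numbers stand for higher lipophilicity and lower numbers for lower lipophilicity), compound 3 gives 3.97 and compound 4 gives 3.84. In the physicochemical assay the same exchange gives a number 0.13 log units lower from compound 3 to compound 4 (within the scatter) so the partition coefficient does not separate the two compounds either, and the position of the fluorine on this ring has no effect that these two read-outs can resolve. No measurement among those shown offers an explanation for this result.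

The compounds shown leave open whether a different group on this ring, such as a methoxy group, an amine or a carboxylic acid in place of the fluorine, would move the number in the histone deacetylase 8 assay beyond the scatter. Going by these compounds, compound 3 and compound 4 are also drawn without a stated configuration at this saturated ring carbon, so how each of their mirror-image forms would read remains open as well.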